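Series notes: the step from compound 3 to compound 4

The source may hold more compounds than are shown below. What is called first, only, known or untested is meant among the compounds shown, and "the series" means these compounds.

In a functional assay on RT-112 cells (Homo sapiens) for antiproliferative activity, read by MTT assay, with a stated time of 72 h (on this read-out lower numbers stand for stronger inhibition of growth and higher numbers for weaker inhibition of growth), compound 1 `COc1cc(Nc2ncnc3c(NC(=O)Nc4ccc(C)cc4C)cccc23)cc(OC)c1` gives 1290 nM and compound 2 `COc1cc(Nc2ncnc3c(NC(=O)Nc4cc(F)cc(F)c4)cccc23)cc(OC)c1` gives 2630 nM.

Compound 3 `COc1cc(Nc2ncnc3c(NC(=O)Nc4ccc(Cl)c(C(F)(F)F)c4)cccc23)cc(OC)c1` gives only a limit, > 20000 nM.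

Compound 4 `COc1cc(Nc2ncnc3c(NC(=O)Nc4ccc5c(c4)OCCO5)cccc23)cc(OC)c1` carries 2,3-dihydro-1,4-benzodioxin-6-yl in place of 4-chloro-3-(trifluoromethyl)phenyl on an amide-type nitrogen.

Three measured exchanges at this same nitrogen bear on the change. Two enter the group that compound 4 loses: an at least 15-fold higher number from compound 1 to compound 3 (1.19 log units; beyond the scatter) is large, and an at least 7.6-fold higher number from compound 2 to compound 3 (0.88 log units; beyond the scatter) is at least modest. The third, a 2.0-fold higher number from compound 1 to compound 2 (0.31 log units; beyond the scatter), is modest and involves neither group.

A sizeable step to a lower number is therefore expected, an at least 8.0-fold lower number from compound 3 to compound 4 (0.90 log units; beyond the scatter).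

Compound 4 is estimated at 2500 nM, with an expected range of 800 nM to 9000 nM.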

Compound 4, concentration for 50% growth inhibition: 2750 nM
Compound 4: the middle estimate sits 1.1-fold (0.04 log units) below what was measured, within the range that was stated.
By their numbers in this assay, from the lowest: compound 1; then compounds 2 and 4 (each within the scatter of the next). At a limit, above all of these: compound 3.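

With 2,3-dihydro-1,4-benzodioxin-6-yl on the amide-type nitrogen, this assay gives an at least 7.2-fold lower number from compound 3 to compound 4 (0.86 log units; beyond the scatter), read against a limit for compound 3: the limit of > 20000 nM in this assay, at which 1 of the 4 values shown sits. A second, non-aromatic ring carrying two oxygens is thus compatible with activity at this nitrogen, with a 1.0-fold higher number from compound 2 to compound 4 (0.02 log units; within the scatter). Compound 1 keeps the lowest number, with a 2.1-fold higher number from compound 1 to compound 4 (0.33 log units; beyond the scatter).

The compounds shown leave open whether the two ring oxygens matter or the fused ring alone sets this level; an indan-5-yl group, with carbon in place of both oxygens, would separate the two. As far as these compounds go, the effect of an amine or a carboxylic acid on this ring also remains open.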